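The compounds below may be only part of what the source reports. "The series", "measured", "known", "first", "only" and "open" are said of these compounds alone.

Measured so far:
compound 1 `CC(C)(C)c1ccc(C(=O)N2CCC3(CC2)C(=O)N(CC(=O)NCCN)CN3c2ccccc2)cc1`: 7000 nM
compound 2 `COC(=O)CCCNC(=O)CN1CN(c2ccccc2)C2(CCN(C(=O)c3ccc(C4CCCCC4)cc3)CC2)C1=O`: 2500 nM
compound 3 `CC(C)(C)OC(=O)NC1CCN(C(=O)CN2CN(c3ccccc3)C3(CCN(C(=O)c4ccc(C5CCCCC5)cc4)CC3)C2=O)CC1`: 4800 nM

All three were tested in an assay on HEK293 cells for displacement of a labelled ligand from NPC1-like intracellular cholesterol transporter 1 (Homo sapiens); on this read-out higher numbers stand for weaker inhibition and lower numbers for stronger inhibition. Compound 1 gives the highest number of the three: compound 3 lies within the usual scatter of it, while compound 2 sits beyond the scatter with a clearly lower number. Compound 4 `CCOC(=O)C1CCCN(C(=O)CN2CN(c3ccccc3)C3(CCN(C(=O)c4ccc(C(C)(C)C)cc4)CC3)C2=O)C1` has not been measured yet. It differs from compound 1 in one place: 3-(ethoxycarbonyl)piperidin-1-yl in place of (2-aminoethyl)amino on a carbonyl carbon. Among the compounds with values here, no measured pair isolates this change, so the expectation rests only on the spread of the three numbers seen so far. The number for compound 4 is expected to come out lower than that of compound 1, by a step of about a 2.0-fold lower number from compound 1 to compound 4 (0.30 log units; within the scatter), roughly at the edge of the scatter. Compound 4 is estimated at 3500 nM, with a likely range from 1500 nM to 8000 nM.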

Compound 4, half-maximal inhibitory concentration: 8200 nM
Beside the measured number, compound 4's estimate is 2.3-fold (0.37 log units) below it; measured number above the stated range.
By their numbers in this assay, from the lowest: compounds 2, 3, 1 and 4 (each within the scatter of the next, the first and the last beyond it).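

In this assay, putting 3-(ethoxycarbonyl)piperidin-1-yl in place of (2-aminoethyl)amino on the carbonyl carbon gives a 1.2-fold higher number from compound 1 to compound 4 (0.07 log units; within the scatter), so compound 1 and compound 4 cannot be told apart. This position therefore accepts a much larger group with a ring and no hydrogen-bond donors without a change beyond the scatter. Nothing available explains why these two groups read alike. Still open, going by these compounds, is whether a carboxylic acid in place of the ethyl ester, or a plain piperidine, would move the number beyond the scatter.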